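This account rests on a few compounds, and the source may have more. Where it says the series, first, only, none or still open, it means among the compounds named here.

Three compounds share one core and differ only in the group on an aromatic carbon of a six-membered aromatic ring with 1 nitrogen, next to the ring nitrogen. Compound 1 `CC(C(=O)NCc1ccc(C(F)(F)F)nc1NCc1ccc(Cl)cc1)c1ccc(NS(C)(=O)=O)c(F)c1` carries (4-chlorobenzyl)amino there and in a functional assay on CHO-K1 cells for antagonist activity at transient receptor potential cation channel subfamily V member 1 (Homo sapiens), read by FLIPR (a higher number here means a weaker inhibitor, a lower number a stronger inhibitor), compound 1 gives 65.7 nM. Compound 2 `CCCCN(C)c1nc(C(F)(F)F)ccc1CNC(=O)C(C)c1ccc(NS(C)(=O)=O)c(F)c1` carries butyl(methyl)amino and gives 0.8 nM. Compound 3 `CC1CCCN1c1nc(C(F)(F)F)ccc1CNC(=O)[C@@H](C)c1ccc(NS(C)(=O)=O)c(F)c1` carries a different amino group and gives 0.3 nM. Compound 2 thus stands second highest of these three numbers, with compound 3 lower and compound 1 far higher.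

Compound 4 `CC(C(=O)NCc1ccc(C(F)(F)F)nc1N1CCC(O)CC1)c1ccc(NS(C)(=O)=O)c(F)c1` is not yet measured. The change from compound 2 is 4-hydroxypiperidin-1-yl in place of butyl(methyl)amino on an aromatic carbon. Within the data shown here, the one measured step at this place is an 82-fold lower number from compound 1 to compound 2 (1.91 log units; beyond the scatter), a large move, so the group here clearly matters. Compounds 2 and 3 show that two different amino groups at this place both give strong inhibitors, while compound 1 shows the only weak one. Among the measured compounds shown here, the hydroxyl carried by the entering group has no measured counterpart here.

Compound 4 is therefore expected at 2 nM, between 0.5 nM and 8 nM, which would be a step of a 2.5-fold higher number from compound 2 to compound 4 (0.40 log units; beyond the scatter).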

Compound 4, inhibition constant: "not active" (no number reported)
The entry for compound 4 holds no number, and the estimate cannot be compared.
By their numbers in this assay, from the lowest: compound 3; then compound 2; then compound 1.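

Among these compounds, compound 4 is recorded as "not active" in this assay with no number, so no step from compound 2 or any other compound to compound 4 can be read. Nothing available accounts for this result. The compounds shown leave open whether the hydroxyl or the ring of 4-hydroxypiperidin-1-yl decides this outcome.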